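Swapping a benzyl for a prenyl chain on a chromane core

The source may report more compounds than this note shows. Statements on the series, on what has been measured and on what is new or still open speak of the compounds shown alone.

Measured compounds and their values in a functional assay on MCF7 cells (Homo sapiens), tested at 5 uM; a higher number here means a weaker effect of the compound at the concentration tested, a lower number a stronger effect:
- compound 1 `CC(C)=CCOc1c(C)c(C)c2c(c1C)CCC(C)(COc1ccc(/C=C3\SC(=O)NC3=O)cc1F)O2`: 87%
- compound 2 `CC(C)=CCOc1c(C)c(C)c2c(c1C)CCC(C)(COc1ccc(/C=C3\SC(=O)NC3=O)cc1-c1ccc(F)cc1)O2`: 92%
- compound 3 `Cc1c(C)c2c(c(C)c1OCc1ccccc1)CCC(C)(COc1ccc(/C=C3\SC(=O)NC3=O)cc1)O2`: 42%

Compound 3 stands lowest of the three numbers, that is, it shows the strongest effect. Its nearest neighbour is compound 1, whose number is higher by a margin beyond the scatter, and compound 2 lies further still, also beyond the scatter.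

Compound 4 `CC(C)=CCOc1c(C)c(C)c2c(c1C)CCC(C)(COc1ccc(/C=C3\SC(=O)NC3=O)cc1)O2` is compound 3 with one change: 2-methylprop-1-en-1-yl in place of phenyl on a saturated chain carbon bound to an oxygen on an aromatic ring. Going by the values given here, only one measured step exists, a number 5 percentage points higher from compound 1 to compound 2 (within the scatter), and it concerns a different place on the molecule, so it says nothing about the change from compound 3 to compound 4. What remains is that compound 1 and compound 2 both carry the 3-methylbut-2-en-1-yl chain that enters here, and both sit in the weak range, while compound 3 with the benzyl sits far lower. Among the compounds with values here, that comparison is the only guide.

Compound 4 is therefore expected to move back toward the values of compound 1 and compound 2, a rise estimated as a number 33 percentage points higher from compound 3 to compound 4 (beyond the scatter). For compound 4 the estimated value in this assay is 75%, within a range from 50% to 95%.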

Compound 4, a percentage reported as activity, at one concentration (the size of the read-out at that concentration, not a potency): 21%
Compound 4: the middle estimate sits 54 percentage points above what was measured; measured number outside the range, below it.
By their numbers in this assay, from the lowest: compound 4; then compound 3; then compounds 1 and 2 (each within the scatter of the next).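

In this assay, exchanging the benzyl group for the 3-methylbut-2-en-1-yl chain gives a number 21 percentage points lower from compound 3 to compound 4 (beyond the scatter), so this chain on the oxygen can go with a stronger effect than benzyl and does not by itself bring the weak numbers seen earlier. Those weak numbers instead follow the other place, the aromatic carbon: with the chain held constant, hydrogen in place of fluoro gives a number 66 percentage points lower from compound 1 to compound 4 (beyond the scatter), and hydrogen in place of 4-fluorophenyl gives a number 71 percentage points lower from compound 2 to compound 4 (beyond the scatter), both large steps beside the modest one at the chain. Nothing measured here explains why either change acts as it does.

On these data alone, it remains open whether fluoro or 4-fluorophenyl on that aromatic carbon would weaken the effect as much in a compound carrying benzyl rather than the 3-methylbut-2-en-1-yl chain. Also open, as far as these compounds go, is how a methoxy group or an amine on that carbon would compare with hydrogen, and how a longer chain such as geranyl would compare with the 3-methylbut-2-en-1-yl chain on the oxygen.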